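Aryl swap on the triazole nitrogen: cyanophenyl analogue

The compounds below may be only part of what the source reports. "The series", "measured", "known", "first", "only" and "open" are said of these compounds alone.

Measured so far in a functional assay on COLO 205 cells (Homo sapiens) for cytotoxicity, read by MTT assay, with a stated time of 24 h; a lower number here means a stronger inhibitor, a higher number a weaker inhibitor:
- compound 1, `COc1ccccc1-n1cc(COc2c(/C=C\C(=O)O)ccc(OC)c2CC=C(C)C)nn1`, 12200 nM
- compound 2, `COc1ccc(/C=C\C(=O)O)c(OCc2cn(-c3ccc(CO)cc3)nn2)c1CC=C(C)C`, 19300 nM

Among the measured compounds shown here, compound 2 carries the higher of the two numbers, with compound 1 as its only neighbour; the step of a 1.6-fold higher number from compound 1 to compound 2 (0.20 log units; within the scatter) lies within the scatter, so the two values cannot be ordered.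

Compound 3, `COc1ccc(/C=C\C(=O)O)c(OCc2cn(-c3ccccc3C#N)nn2)c1CC=C(C)C`, is the next member. The change is 2-cyanophenyl in place of 4-(hydroxymethyl)phenyl on an aromatic nitrogen. For the measured compounds named here, the only step that bears on it is the earlier aryl exchange on the same nitrogen, a 1.6-fold higher number from compound 1 to compound 2 (0.20 log units; within the scatter), which stayed within the scatter. A second aryl exchange at this position is therefore expected to give no step beyond the scatter in this assay , i.e. an expected step of a 1.3-fold lower number from compound 2 to compound 3 (0.11 log units; within the scatter). The estimate for compound 3 is 15000 nM, with a range from 6000 nM to 40000 nM.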

Compound 3, half-maximal inhibitory concentration: 3200 nM
For compound 3 the middle estimate is 4.7-fold (0.67 log units) above the measured one; the measured number lies below the stated range.
By their numbers in this assay, from the lowest: compound 3; then compounds 1 and 2 (each within the scatter of the next).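

Notes on the aryl group on the aromatic nitrogen of the five-membered ring: in this assay, an exchange at this position can move the number beyond the scatter (a 6.0-fold lower number from compound 2 to compound 3 (0.78 log units; beyond the scatter)), which the exchange between compounds 1 and 2 did not show. Among the compounds shown here, the cleanest comparison is the single change of cyano in place of methoxy on an aromatic carbon (a 3.8-fold lower number from compound 1 to compound 3 (0.58 log units; beyond the scatter)), so the gain does not depend on the loss of the 4-(hydroxymethyl)phenyl group alone. No measurement here accounts for either step.

The compounds shown leave open whether the gain is specific to the nitrile or would also appear with another group on the same aromatic carbon, such as an amine or a carboxylic acid. They also leave open whether a longer chain ending in a nitrile would keep it.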